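A few compounds are considered here, and "the series" means these few. Any claim that something is new, unique, unknown or untested is made for them only; others in the source may bear on it.

These compounds share the core of compound 1 and were tested in an assay on isolated protein for inhibition of Dihydrofolate reductase (Homo sapiens), read by spectrophotometry, using NADPH, with stated times of 5 s and 6 min; on this read-out higher numbers stand for weaker inhibition and lower numbers for stronger inhibition. Compound 1 `NC1=NC2(CCSCC2)N(OCCCOc2ccc(Br)cc2)C(N)=N1` gives 6.46 nM in this assay. Compound 2 `NC1=NC2(CCOCC2)N(OCCCOc2ccccc2Cl)C(N)=N1` is entered in this assay as "not determined" (no result reported), so no number stands for it. The same holds for compound 3 `NC1=NC2(CCSCC2)N(OCCCOc2ccccc2Cl)C(N)=N1`, which is entered in this assay as "not determined" (no result reported). Within the data shown here, compound 2 therefore stands without a value of its own, and there is no measured step from it to any other compound.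

Compound 4 `Cc1ccc(OCCCON2C(N)=NC(N)=NC23CCOCC3)cc1` has not yet been measured. It differs from compound 2 in one place: 4-methylphenyl in place of 2-chlorophenyl on an oxygen on a saturated carbon. Among the measured compounds shown here, with no value for compound 2 and no measured pair in which this same change has been made, no step can be computed, and its direction is open; a swap of one aromatic ring for another of the same size could well stay within the usual scatter, or shift the inhibitory concentration modestly either way. For the measured compounds named here, the only anchor is compound 1, whose value of 6.46 nM shows that a close relative carrying a different saturated ring and a different aromatic ring inhibits the enzyme at a low concentration. On that basis compound 4 is expected to give about 15 nM in this assay, with a plausible range from 4 nM to 60 nM.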

Compound 4, half-maximal inhibitory concentration: 56.8 nM
Compound 4: middle estimate off by 3.8-fold (0.58 log units), on the low side; the measured number falls inside the stated range.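

In this assay, among these compounds, compound 4 gives 56.8 nM but compound 2 has no number, so no step between these two compounds can be read. Nothing shown here bears on the reason for this result. On these data alone, what replacing 2-chlorophenyl with 4-methylphenyl does to inhibition of the enzyme stays open.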